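The compounds below may be only part of what the source reports. "The series", "measured", "known", "first", "only" and "open" are said of these compounds alone.

Measured so far:
- compound 1, `CCn1nc(CC2(OC)C(=O)N(CC(=O)N(c3ccc(OC)cc3)C(C)C)C=CN(c3ccccc3)C2=O)c2ccccc21`: 31600 nM; > 30000 nM (2 entries)
- compound 2, `COc1ccc(N(C(=O)CN2C=CN(c3ccccc3)C(=O)C(Cc3n[nH]c4ccccc34)C2=O)C(C)C)cc1`: 29.5 nM
- compound 3, `CC(C)N(C(=O)CN1C=CN(c2ccccc2)C(=O)[C@H](Cc2n[nH]c3ccccc23)C1=O)c1ccccc1`: 295 nM

All three compounds were tested in a functional assay on CHO cells for agonist activity at Melanocyte-stimulating hormone receptor (Homo sapiens), read by a luciferase reporter, with a stated time of 4 h; a higher number here means that more compound is needed for the effect, a lower number that less compound is needed. Among the measured compounds shown here, compound 1 stands apart: in the several entries of compound 1 in this assay, 31600 nM; > 30000 nM (2 entries) two of its entries are limits of the assay rather than numbers, and its one number is far higher than the others. Among the compounds with a single number, compound 2 gives the lower value, and compound 3 gives the highest, well beyond the scatter from compound 2.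

Compound 4, `O=C1[C@@H](Cc2n[nH]c3ccccc23)C(=O)N(c2ccccc2)C=CN1CC(=O)N1CCCCc2ccccc21`, has not yet been measured in this assay. It differs from compound 3 in one place: a group of 11 heavy atoms (10 carbon, 1 nitrogen; one six-membered aromatic ring of carbon only, one seven-membered non-aromatic ring with 1 hetero atom) in place of a group of 10 heavy atoms (9 carbon, 1 nitrogen; one six-membered aromatic ring of carbon only), on a carbonyl carbon. In words, a group of 11 heavy atoms (10 carbon, 1 nitrogen; one six-membered aromatic ring of carbon only, one seven-membered non-aromatic ring with 1 hetero atom) takes the place of a group of 10 heavy atoms (9 carbon, 1 nitrogen; one six-membered aromatic ring of carbon only), on a carbonyl carbon. For the measured compounds named here, no measured pair shows this change, so the direction of the step is open; the expectation is a step that stays within the scatter, or at most a modest one either way, given in a 1.0-fold higher number from compound 3 to compound 4 (0.01 log units; within the scatter). For compound 4 the estimate in this assay is 300 nM, with a range from 80 nM to 1200 nM.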

Compound 4, half-maximal effective concentration: 1.59 nM
Beside the measured number, compound 4's estimate is 190-fold (2.28 log units) above it, and the stated range ends above it.
By their numbers in this assay, from the lowest: compound 4; then compound 2; then compound 3.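

In this assay, among the compounds shown here, the group on this carbonyl carbon turns out to have a very large influence on the number, which the earlier compounds could not show because none of them varied it alone: the change gives a 190-fold lower number from compound 3 to compound 4 (2.27 log units; beyond the scatter). The step is large even though the two groups look alike in the computed counts, as both hold one six-membered aromatic ring of carbon only, no hydrogen-bond donors or acceptors and no net charge, so what visibly separates them is the seven-membered non-aromatic ring in the entering group. Nothing in the available evidence bears on why this single change has so large an effect.

This is one step at one position, so it cannot tell whether the seven-membered ring itself matters, or whether the aromatic ring attached to it is also needed. A piperidine or a morpholine on the same carbonyl carbon, or a fluorine on the aromatic ring of the entering group, would be the kind of neighbouring change needed to separate these possibilities.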